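Compound 1 to compound 4: naphthalen-2-yl on the sulfur

The source may report more compounds than this note shows. Statements on the series, on what has been measured and on what is new or still open speak of the compounds shown alone.

compound 1 `O=C(CSc1ncc[nH]1)Nc1ccc2nc(NC(=O)c3ccc(C(F)(F)F)cc3)sc2c1` gives 18800 nM
compound 2 `O=C(CSc1cccc(O)c1)Nc1ccc2nc(NC(=O)c3ccc(F)cc3)sc2c1` gives 5120 nM
compound 3 `Cn1c(CNC(=O)c2cccs2)nnc1SCC(=O)Nc1cccc(Cl)c1` gives > 100000 nM as a limit

All three values come from a functional assay on U2OS cells (Homo sapiens) for antiproliferative activity, read by MTT assay, with a stated time of 72 h (a higher number here means a weaker inhibitor, a lower number a stronger inhibitor), and compound 1 holds the higher of the two actual numbers, with compound 2 lower by more than the scatter. The reading for compound 3 is a limit, not a number.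

Among the compounds with values here, compound 4 `O=C(CSc1ccc2ccccc2c1)Nc1ccc2nc(NC(=O)c3ccc(C(F)(F)F)cc3)sc2c1` carries naphthalen-2-yl in place of 1H-imidazol-2-yl on a sulfur and no measured pair isolates this change. The expectation leans on compound 2, which gives 5120 nM and also has a six-membered aromatic ring on that sulfur, though it differs elsewhere too. A moderate move toward a lower number is expected, an estimated 2.4-fold lower number from compound 1 to compound 4 (0.37 log units; beyond the scatter) in this assay. For compound 4 the estimate is 8000 nM with an expected range of 2500 nM to 25000 nM.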

Compound 4, half-maximal inhibitory concentration: 3940 nM
Compound 4: the middle estimate sits 2.0-fold (0.31 log units) above what was measured; low and high end bracket the measured number.
By their numbers in this assay, from the lowest: compounds 4 and 2 (each within the scatter of the next); then compound 1. At a limit, above all of these: compound 3.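

In this assay, within the data shown here, this is the first step that isolates the group on the sulfur: naphthalen-2-yl in place of 1H-imidazol-2-yl gives a 4.8-fold lower number from compound 1 to compound 4 (0.68 log units; beyond the scatter). The place on the sulfur therefore accepts 10 heavy atoms, all carbon, with no hydrogen-bond donor or acceptor, and the number still falls. Nothing measured here gives a cause for this step.

Still open, going by these compounds, is whether cyclohexyl, a saturated carbon ring, on the sulfur would keep this step. Also open, on these data alone, is whether an amine or a carboxylic acid on the naphthalen-2-yl rings would keep it.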